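Adding a Second Trifluoromethyl to a Compound at the Limit

A few compounds are considered here, and "the series" means these few. Any claim that something is new, unique, unknown or untested is made for them only; others in the source may bear on it.

Of the compounds shown here, three have been tested in a functional assay on HeLa cells (Homo sapiens) for inhibition, read by MTT assay, with a stated time of 72 h; a lower number here means a stronger inhibitor, a higher number a weaker inhibitor. Compound 1 `CN(C(=O)NC(=O)c1ccc(Cl)c(Cl)c1)c1nc(C(F)(F)F)c(C(=O)N/N=C/c2ccc([N+](=O)[O-])cc2)s1` gives 5.12 ug/mL, and compound 2 `CN(C(=O)NC(=O)c1ccccc1)c1nc(C(F)(F)F)c(C(=O)N/N=C/c2cccc([N+](=O)[O-])c2)s1` gives 11.2 ug/mL. Compound 3 `CNc1nc(C)c(C(=O)N/N=C/c2cccc(C(F)(F)F)c2)s1` is reported only as a limit, > 100 ug/mL, so no number was obtained for it. Among the values shown, compound 3 therefore stands apart: the other two carry numbers, while compound 3 sits at the limit of > 100 ug/mL in this assay, at which 1 of the 3 values shown sits.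

Compound 4 `CNc1nc(C)c(C(=O)N/N=C/c2cc(C(F)(F)F)cc(C(F)(F)F)c2)s1` has not yet been measured. It differs from compound 3 in one place: trifluoromethyl in place of hydrogen on an aromatic carbon. Within the data shown here, no measured pair shows what this kind of change does here, and compound 3 itself offers only a limit, so there is no number from which a step could be read. The plain expectation is that compound 4 behaves much like compound 3 and again falls at or near the limit. For compound 4 the step is expected to stay within the scatter, a step that the limit leaves unreadable from compound 3 to compound 4. Compound 4 is accordingly estimated at 120 ug/mL, somewhere between 30 ug/mL and 400 ug/mL, with a real chance that only a limit is reported once more.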

Compound 4, half-maximal inhibitory concentration: > 100 ug/mL
Compound 4: no number, only a limit; the forecaster's own chance of this, stated with the estimate: 70%; the middle value lies beyond the limit too.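

Compound 3 and compound 4 are both reported only as limits in this assay, so no step can be read between them: the limit of > 100 ug/mL in this assay, at which 2 of the 4 values shown sit.

The compounds shown leave open what the added trifluoromethyl does to inhibition, whether weakening it, strengthening it or leaving it unchanged.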